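Buffer half-life across three aryl substituents

The compounds below may be only part of what the source reports. "The series", "measured", "known", "first", "only" and "open" are said of these compounds alone.

Compound 1 `C=Cc1cc(C(F)(F)F)cc(C(F)(F)F)c1`: > 50 h, a limit
Compound 2 `C#Cc1cc(C(F)(F)F)cc(C(F)(F)F)c1`: 1.6 h

In an ADME assay for pharmacokinetics, read by LC-MS, in phosphate buffer, with a stated time of 72 h, at pH 7.4, tested at 250 uM (on this read-out lower numbers stand for a shorter-lived compound and higher numbers for a longer-lived compound), compound 1 gives > 50 h, which is a limit of the assay and not a number. Compound 2 gives 1.6 h, the only plain number shown. Among the measured compounds shown here, the single measured step is an at least 31-fold lower number from compound 1 to compound 2 (1.49 log units; beyond the scatter). Compound 3 `N#Cc1cc(C(F)(F)F)cc(C(F)(F)F)c1` differs from compound 2 by cyano in place of ethynyl on an aromatic carbon. For the measured compounds named here, no measured step covers this change, so its size and direction cannot be taken from the one step known. Compound 3 is nevertheless expected to give 40 h, between 5 h and 200 h, an expected step of a 25-fold higher number from compound 2 to compound 3 (1.40 log units; beyond the scatter).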

Compound 3, half-life: > 50 h
Compound 3: no number, only a limit (the forecaster's own chance of this, stated with the estimate: 50%); at least 1.2-fold (0.09 log units) between middle value and limit.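

At this position on the shared core, only ethynyl among the three groups goes with a short half-life: cyano in its place gives an at least 31-fold higher number from compound 2 to compound 3 (1.49 log units; beyond the scatter). Compound 3 also keeps a triple bond outside aromatic rings, so that feature alone does not go with a short half-life in this assay. The step between compound 1 and compound 3 cannot be read, because both sit at one limit: the limit of > 50 h in this assay, at which 2 of the 3 values shown sit.

From the compounds shown here alone, how an amine or a carboxylic acid would behave at this position remains open. So does whether ethynyl on a longer chain would behave as it does on the aromatic carbon.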